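From 2-methoxyphenyl to 3-methoxyphenyl on compound 3

A few compounds are considered here, and "the series" means these few. Any claim that something is new, unique, unknown or untested is made for them only; others in the source may bear on it.

In a physicochemical assay for solubility, tested at 500 uM (on this read-out lower numbers stand for lower solubility and higher numbers for higher solubility), compound 1 (`COC(=O)c1ccccc1OCc1oc(-c2ccccc2OC)nc1C`) gives 185000 nM, compound 2 (`COC(=O)c1ccccc1OCc1oc(-c2cccc(OC)c2)nc1C`) gives 52800 nM and compound 3 (`COC(=O)c1cccc(OCc2oc(-c3ccccc3OC)nc2C)c1`) gives 44100 nM. Compound 3 lies within the scatter of compound 2, and both lie beyond the scatter under compound 1.

Compound 4 (`COC(=O)c1cccc(OCc2oc(-c3cccc(OC)c3)nc2C)c1`) differs from compound 3 by one change, 3-methoxyphenyl in place of 2-methoxyphenyl on an aromatic carbon.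

Among the measured compounds shown here, the only measured step with this change is a 3.5-fold lower number from compound 1 to compound 2 (0.54 log units; beyond the scatter), modest and beyond the scatter. It is a single precedent, taken from a different starting compound, so a lower number of similar or somewhat smaller size is expected. The estimated step is a 2.9-fold lower number from compound 3 to compound 4 (0.47 log units; beyond the scatter). Compound 4 is estimated at 15000 nM, with an expected range of 6000 nM to 40000 nM.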

Compound 4, solubility: 24100 nM
The estimate for compound 4 lay 1.6-fold (0.21 log units) below the measured number; the range from low to high includes it.
By their numbers in this assay, from the lowest: compounds 4, 3 and 2 (each within the scatter of the next, the first and the last beyond it); then compound 1.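

In this assay, 3-methoxyphenyl in place of 2-methoxyphenyl gives a 1.8-fold lower number from compound 3 to compound 4 (0.26 log units; within the scatter), whereas the same change earlier gave a 3.5-fold lower number from compound 1 to compound 2 (0.54 log units; beyond the scatter). The second reading therefore does not confirm a change beyond the scatter on the core of compound 3, so the clear step seen on compound 1 cannot be assumed to carry over to every core in the series. No measurement shown gives a cause for either step.

Still open, as far as these compounds go, is how 4-methoxyphenyl would read at this position. A carboxylic acid in place of the methyl ester also remains to be placed in this assay.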